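The source may report more compounds than this note shows. Statements on the series, on what has been measured and on what is new or still open speak of the compounds shown alone.

Compound 1 `CN(C)c1ccc(C2CC(c3cc4ccccc4o3)=NN2C(=O)c2ccncc2)cc1`: in an ADME assay on Vero cells (Chlorocebus sabaeus) for cytotoxicity, read by MTT assay, with a stated time of 72 h (a higher number here means a weaker inhibitor, a lower number a stronger inhibitor), compound 1 gives > 210000 nM, which is a limit of the assay, not a number.
Compound 2 `O=C(O)c1ccccc1C1CC(c2cc3ccccc3o2)=NN1C(=O)c1ccncc1`: in this assay compound 2 gives > 170000 nM, also a limit.
Compound 3 `CCn1cc(C(=O)N2N=C(c3cc4ccccc4o3)CC2c2ccc(N(C)C)cc2)c(=O)c2ccc(C)nc21`: in this assay compound 3 gives > 206000 nM, again a limit.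

Compound 4 `CCn1cc(C(=O)N2N=C(c3cc4ccccc4o3)CC2c2ccccc2C(=O)O)c(=O)c2ccc(C)nc21` has not been measured. The change from compound 1 to compound 2 is 2-carboxyphenyl in place of 4-(dimethylamino)phenyl on a saturated ring carbon; its step was a step that the two limits leave unreadable from compound 1 to compound 2. The same kind of change leads from compound 3 to compound 4, namely (2-carboxyphenyl in place of 4-(dimethylamino)phenyl on a saturated ring carbon), but here the saturated ring carbon is next to the ring atom that bears a large group, whereas in compound 1 that ring atom bears a (pyridin-4-yl)carbonyl group (8 heavy atoms). How the core of compound 1 and the core of compound 3 differ is not broken down here. Because the like step that the two limits leave unreadable from compound 1 to compound 2 cannot be read, the step expected from compound 3 to compound 4 is an at least 1.0-fold lower number from compound 3 to compound 4 (0.01 log units; that floor lies within the scatter), resting only on that parallel. Compound 4 is expected to give about 200000 nM, somewhere from 100000 nM to 400000 nM, most likely once more only a limit.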

Compound 4, half-maximal inhibitory concentration: > 196000 nM
Compound 4: a limit, no number; the forecaster's own chance of this, stated with the estimate: 85%; the middle value does not contradict the limit.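

Compound 3 and compound 4 both give only limits in this assay, and the step between them cannot be read. The compounds shown leave open whether 2-carboxyphenyl in place of 4-(dimethylamino)phenyl changes the read-out at all.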